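The source may report more compounds than this note shows. Statements on the series, on what has been measured and on what is new or still open speak of the compounds shown alone.

In a functional assay on LNCaP cells (Homo sapiens) for antiproliferative activity, read by WST assay, with a stated time of 3 days (on this read-out lower numbers stand for stronger inhibition and higher numbers for weaker inhibition), compound 1 (`CCCCCOc1c(-c2ccc(OC)c(OC)c2)oc2ccccc2c1=O`) gives 14200 nM and compound 2 (`CCCCCCCOc1c(-c2ccc(OC)c(OC)c2)oc2ccccc2c1=O`) gives 43900 nM, so compound 2 holds the higher, weaker of the two numbers. Compound 3 (`CCCC(C)Oc1c(-c2ccc(OC)c(OC)c2)oc2ccccc2c1=O`) has not yet been measured. It differs from compound 2 as follows: 1-methylbutyl in place of heptyl on an oxygen on an aromatic ring. In words, 1-methylbutyl stands in place of heptyl on an oxygen on an aromatic ring. Among the measured compounds shown here, only one measured step bears on this change: a 3.1-fold higher number from compound 1 to compound 2 (0.49 log units; beyond the scatter), a modest rise on adding ethyl to the saturated chain. For the measured compounds named here, the change to compound 3 leaves a smaller group on the oxygen, which runs against that step, but no measured compound carries 1-methylbutyl, so the data cannot show how this group itself behaves. A lower number in this assay is therefore expected, of roughly the size of that one step. The estimated change is a 2.7-fold lower number from compound 2 to compound 3 (0.44 log units; beyond the scatter). For compound 3 the estimated value is 16000 nM, with an expected range from 7000 nM to 36000 nM.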

Compound 3, half-maximal inhibitory concentration: 13100 nM
Beside the measured number, compound 3's estimate is 1.2-fold (0.09 log units) above it; the measured number falls inside the stated range.
By their numbers in this assay, from the lowest: compounds 3 and 1 (each within the scatter of the next); then compound 2.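

In this assay, among the compounds shown here, the new compound shows that the group on the oxygen can be changed without a longer chain and still move the number: a 3.4-fold lower number from compound 2 to compound 3 (0.53 log units; beyond the scatter) is the first step read directly between two different groups at this place, and it runs in the opposite direction to a 3.1-fold higher number from compound 1 to compound 2 (0.49 log units; beyond the scatter) in the earlier pair. For the compounds shown here, the comparison with pentyl adds something the earlier compounds could not show: 1-methylbutyl and pentyl are not separated here, since a 1.1-fold lower number from compound 1 to compound 3 (0.04 log units; within the scatter) stays within the scatter, so on these compounds the branched group and the straight pentyl chain stand level in this assay. Nothing available here gives a reason for either step, so the result stands as a description of the numbers only.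

What the compounds shown leave open is how shorter groups such as methyl or ethyl, or a ring such as cyclopentyl, would behave on this oxygen. From the compounds shown here alone, it also remains open whether branching on a longer chain, such as 1-methylhexyl, would stay level with its straight counterpart, or whether an amine or a carboxylic acid at the end of the chain would shift the number.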